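Same Atoms, Joined Differently: Estimating Compound 4

The compounds below may be only part of what the source reports. "The series", "measured", "known", "first", "only" and "open" are said of these compounds alone.

Of the compounds shown here, three sharing one core have been tested in a functional assay on NCI-H1581 cells (Homo sapiens) for inhibition, read by MTT assay, with a stated time of 48 h, tested at 10 uM; on this read-out higher numbers stand for more inhibition at the one concentration tested (going by the name of the read-out) and lower numbers for less inhibition. Compound 1 `COc1cc(NC(=O)Nc2cc(Nc3ccc(C(C)(C)C)cc3)ncn2)cc(OC)c1` gives 38.7%, compound 2 `Cc1ccc(Nc2cc(NC(=O)Nc3c(Cl)cccc3Cl)ncn2)cc1F` gives 45.3%, and compound 3 `CCc1ccc(Nc2cc(NC(=O)Nc3cc(OC)cc(OC)c3)ncn2)cc1` gives 32.7%. Compound 3 sits at the low end of these three numbers: its gap to compound 1 lies within the usual scatter of this assay, while compound 2 stands beyond that scatter above it.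

For the measured compounds named here, the only step between two compounds that differ in one place is a number 6 percentage points lower from compound 1 to compound 3 (within the scatter), a change on the same outer ring that compound 4 alters, and it stayed within the scatter.

Compound 4 `COc1cc(NC(=O)Nc2cc(Nc3ccc(C)c(C)c3)ncn2)cc(OC)c1` differs from compound 3 by 3,4-dimethylphenyl in place of 4-ethylphenyl on a nitrogen on an aromatic ring. The two compounds hold the same atoms joined differently. Going by the values given here, since the one related step, from compound 1 to compound 3, was within the scatter, a step of no more than the scatter is expected in this assay, in no clear direction.

On that basis compound 4 is estimated at 36%, with a range from 20% to 52%, meaning an expected step of a number 3.3 percentage points higher from compound 3 to compound 4 (within the scatter).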

Compound 4, a percentage reported as inhibition, at one concentration (the size of the read-out at that concentration, not a potency): 20.1%
Estimate against measurement, compound 4: 15.9 percentage points above; low and high end bracket the measured number.
By their numbers in this assay, from the lowest: compound 4; then compounds 3, 1 and 2 (each within the scatter of the next, the first and the last beyond it).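

In this assay, the group on this nitrogen turns out to matter in how its carbons are arranged, not only in how many there are: 4-ethylphenyl and 3,4-dimethylphenyl have the same heavy-atom count, yet exchanging them gives a number 12.6 percentage points lower from compound 3 to compound 4 (beyond the scatter). The earlier change at this place, from tert-butyl to ethyl on the ring, stayed within the scatter and gave no sign of this. Replacing the 4-(tert-butyl)phenyl directly with 3,4-dimethylphenyl also goes beyond the scatter, with a number 18.6 percentage points lower from compound 1 to compound 4 (beyond the scatter), so both steps beyond the scatter at this place lead to the 3,4-dimethylphenyl group.

Going by these compounds, how this ring would fare carrying a morpholine or a carboxylic acid remains open. Nothing available explains why rearranging these carbons lowers the inhibition.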